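Series notes: methoxy to hydrogen on the pyridin-2-yloxy group

The source may hold more compounds than are shown below. What is called first, only, known or untested is meant among the compounds shown, and "the series" means these compounds.

In a functional assay on CHO cells for positive allosteric modulation of muscarinic acetylcholine receptor M5 (Homo sapiens), read by FLIPR and calcium flux, with a stated time of 1 h (on this read-out higher numbers stand for larger maximal responses and lower numbers for smaller maximal responses), compound 1 `O=C1C(=O)N(Cc2ccc(-c3ccccc3)cn2)c2ccc(OC(F)(F)F)cc21` gives 47%. Compound 2 `COc1cccc(Oc2ccc(CN3C(=O)C(=O)c4cc(OC(F)(F)F)ccc43)cc2)n1` gives 51%, the higher of the two numbers, yet the gap to compound 1 lies within the scatter, so no order between them is claimed. Compound 3 `O=C1C(=O)N(Cc2ccc(Oc3ccccn3)cc2)c2ccc(OC(F)(F)F)cc21` differs from compound 2 by hydrogen in place of methoxy on an aromatic carbon. Within the data shown here, no step between measured compounds is available, so only the two values and the change itself inform the expectation. Removing the methoxy is expected to shift the maximal response little, if at all, beyond the scatter, in no clear direction. Compound 3 is expected to give about 46%, between 30% and 62%. This expectation corresponds to a number 5 percentage points lower from compound 2 to compound 3 (within the scatter).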

Compound 3, largest response reached (Emax), in percent of the reference or control that the assay uses: 46%
Beside the measured number, compound 3's estimate shows no gap at the digits printed, and the stated range covers the measured number.
By their numbers in this assay, from the lowest: compounds 3, 1 and 2 (each within the scatter of the next).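

Going from methoxy to hydrogen on the carbon next to the ring nitrogen, the 6-methoxypyridin-2-yl to pyridin-2-yl change gives in this assay a number 5 percentage points lower from compound 2 to compound 3 (within the scatter). Among these compounds, the maximal response at this position therefore does not depend measurably on the methoxy, which the earlier compounds could not show. Nothing available accounts for this result.

On these data alone, only methoxy and hydrogen are compared at this carbon, so the response with an amine, a fluorine or an ethoxy chain there remains open. As far as these compounds go, whether the same change behaves alike on other members also remains open.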